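Replacing a bromophenyl arm with a nitropiperazinyl group

The source may report more compounds than this note shows. Statements on the series, on what has been measured and on what is new or still open speak of the compounds shown alone.

Compound 1, `O=C(O)c1ccc(C(=O)/C(=C\c2ccc(Br)cc2)SCc2ccc(Br)cc2)cc1`, in a functional assay on DU-145 cells (Homo sapiens) for inhibition, read by trypan blue exclusion, with a stated time of 96 h (a lower number here means a stronger inhibitor of growth, a higher number a weaker inhibitor of growth), gives 1000 nM.
Compound 2, `O=C(/C(=C\c1ccc(F)cc1Cl)Sc1ccc(Br)cc1)c1ccc(Br)cc1`, in this assay gives 1000 nM.
Compound 3, `Cc1ccc(CS/C(=C/c2ccc(O)c(O)c2O)C(=O)c2ccc(Cl)cc2)cc1`, in this assay gives 50000 nM.

On these numbers compound 1 and compound 2 sit level at the digits shown, within the usual scatter, and together they hold the lowest numbers of the three. Compound 3 lies far above both, a gap well beyond the scatter. Within the data shown here, no two of the measured compounds differ from one another in a single place, so no measured step of one change is available here, and any expectation for a new compound rests on the structures alone.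

Compound 4, `CN1CCN(/C=C(/SCc2ccc(Br)cc2)C(=O)c2ccc(C(=O)O)cc2)CC1[N+](=O)[O-]`, has not yet been measured in this assay. It differs from compound 1 in one place: 4-methyl-3-nitropiperazin-1-yl in place of 4-bromophenyl on a double-bonded chain carbon bound to a double-bonded chain carbon. Among the measured compounds shown here, nothing among the measured compounds tests a change of this kind, so the direction is a judgement rather than a reading from data. The step from compound 1 to compound 4 is expected to go upward, toward weaker inhibition of growth, by about a 5.0-fold higher number from compound 1 to compound 4 (0.70 log units; beyond the scatter). Compound 4 is accordingly expected to give roughly 5000 nM, with a likely range from 1000 nM to 30000 nM.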

Compound 4, concentration for 50% growth inhibition: 10000 nM
Estimate against measurement, compound 4: 2.0-fold (0.30 log units) below; the range from low to high includes it.
By their numbers in this assay, from the lowest: compounds 1 and 2 (each within the scatter of the next); then compound 4; then compound 3.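

In this assay, among these compounds, replacing 4-bromophenyl with 4-methyl-3-nitropiperazin-1-yl on a double-bonded chain carbon bound to a double-bonded chain carbon gives a 10-fold higher number from compound 1 to compound 4 (1.00 log units; beyond the scatter), the first measured step of one change in this set. It shows that this position is not indifferent to what it carries, while the exchange of an aromatic carbon ring for a non-aromatic ring with hetero atoms still leaves compound 4 with a measured value of 10000 nM for growth inhibition. No measurement bears on what lies behind this step.

The nitro group, the methyl group and the loss of the aromatic ring all enter together in this one step, and the compounds shown leave open how much of the change belongs to each; an unsubstituted piperazine or a morpholine at this place would speak to that question. Also open is whether a step of this size would recur on the other cores shown here, such as that of compound 2, which carries no carboxylic acid.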